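The source may hold more compounds than are shown below. What is called first, only, known or untested is meant among the compounds shown, and "the series" means these compounds.

Measured so far in a physicochemical assay for solubility, with a stated time of 3 days, at pH 2; a higher number here means a more soluble compound, a lower number a less soluble compound:
- compound 1 `NC(=O)c1ccc2[nH]c(-c3ccc(OC4CCCNC4)cc3)nc2c1`: > 400000 nM
- compound 2 `NC(=O)c1ccc2[nH]c(-c3ccc(OCCCN4CCCCC4)cc3)nc2c1`: > 400000 nM

Compound 1 gives only a limit of the assay in this assay, > 400000 nM, not a number. Compound 2 likewise gives only a limit in this assay, > 400000 nM. Both values sit at the limit of > 400000 nM in this assay, at which 2 of the 2 values shown sit, so no direction of change is readable between them; the step that the two limits leave unreadable from compound 1 to compound 2 is unreadable for that reason.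

Compound 3 `CN1CCC(Oc2ccc(-c3nc4cc(C(N)=O)ccc4[nH]3)cc2)CC1` is not yet measured in this assay. It differs from compound 1 by 1-methylpiperidin-4-yl in place of piperidin-3-yl on an oxygen on an aromatic ring.

Among the compounds with values here, the only measured step that touches the same oxygen on the aromatic ring is the one from compound 1 to compound 2, and it gives no size. Nothing else in the series bears on the change. The shared core is unchanged, and compound 1 already stands at the limit; no step beyond the scatter in either direction can be read from the numbers shown.

Compound 3 is therefore expected to give 400000 nM in this assay, within a range of 200000 nM to 800000 nM. The expected step from compound 1 to compound 3 is estimated as a number no higher from compound 1 to compound 3 (the limit leaves the size open), and a further limit rather than a number is the likelier read-out.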

Compound 3, solubility: > 400000 nM
Compound 3 gave a limit, no number; the forecaster's own chance of this, stated with the estimate: 75%; the middle value sits exactly at the limit.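

In this assay compound 3 gives > 400000 nM, which is a limit and not a number. No step among compound 1, compound 2 and compound 3 can be read, because each value is a limit: the limit of > 400000 nM in this assay, at which 3 of the 3 values shown sit.

The compounds shown leave open whether piperidin-3-yl, 3-(piperidin-1-yl)propyl and 1-methylpiperidin-4-yl on the oxygen differ at all in this assay.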